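This account rests on a few compounds, and the source may have more. Where it says the series, first, only, none or still open, it means among the compounds named here.

In an ADME assay on GES1 cells (Homo sapiens) for inhibition, read by MTT assay, with a stated time of 72 h (a higher number here means a weaker inhibitor, a lower number a stronger inhibitor), compound 1 `Cc1cc(Nc2cc(-c3ccccc3)[nH]n2)n2nc(SCc3ccc(F)cc3)nc2n1` gives 35500 nM and compound 2 `Cc1cc(Nc2cc(-c3ccccc3)[nH]n2)n2nc(SCc3nc4ccccc4[nH]3)nc2n1` gives 27800 nM. These values lie within the scatter of each other, so compound 2 cannot be told apart from compound 1. Compound 3 `CCCSc1nc2nc(C)cc(Nc3cc(-c4ccccc4)[nH]n3)n2n1` keeps the shared core and differs from compound 2 in one place: ethyl in place of 1H-benzimidazol-2-yl on a saturated chain carbon bound to a sulfur. Going by the values given here, only one measured step bears on this change. It falls at the same place, and a 1.3-fold lower number from compound 1 to compound 2 (0.11 log units; within the scatter). That step swaps one ring-bearing group for another, whereas this change leaves no ring on the chain, so it is only a loose guide. The expected change is small, a 1.1-fold higher number from compound 2 to compound 3 (0.03 log units; within the scatter), with no step beyond the scatter anticipated. For compound 3 the estimated value is 30000 nM, with an expected range of 13000 nM to 65000 nM.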

Compound 3, half-maximal inhibitory concentration: > 50000 nM
Compound 3: a limit, no number (the forecaster's own chance of this, stated with the estimate: 15%); middle value at least 1.6-fold (0.22 log units) away from the limit.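

In this assay compound 3 gives > 50000 nM, which is a limit of the assay and not a number. The change can therefore be read only as floors, an at least 1.7-fold higher number from compound 2 to compound 3 (0.25 log units; that floor lies within the scatter) and an at least 1.4-fold higher number from compound 1 to compound 3 (0.14 log units; that floor lies within the scatter), and because each floor lies within the scatter, neither step establishes a real difference. What is new at this position is that both ring-bearing groups on the chain carbon gave numbers, whereas the ring-free propylsulfanyl chain gives only a limit.

The compounds shown cannot separate the loss of a ring from the shortening of the group, and a longer chain such as hexyl could help to address that. From the compounds shown here alone, it also remains open how an amine or a carboxylic acid at the end of the chain would read in this assay.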